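Chloro to Methyl on a Core That Shows No Binding

The source may hold more compounds than are shown below. What is called first, only, known or untested is meant among the compounds shown, and "the series" means these compounds.

Of the compounds shown here, two have been tested in an assay on MCF7 cells for inhibition of Serine-protein kinase ATM (Homo sapiens), read by immunofluorescence, with a stated time of 1 h; a lower number here means a stronger inhibitor, a higher number a weaker inhibitor. Compound 1 `Nc1nc(-c2ccccc2)nn1-c1ncnc2cc(Cl)ccc12` returns only the limit of the test, > 40000 nM. Compound 2 `COc1cc2nc(Cl)nc(-n3nc(-c4ccccn4)nc3N)c2cc1OC` likewise returns only a limit, > 40000 nM. For the measured compounds named here, compound 2 therefore stands at the edge of what this assay can report, with no measurable inhibition, and the one other value shown sits at the same place (the limit of > 40000 nM in this assay, at which 2 of the 2 values shown sit). Compound 3 `COc1cc2nc(C)nc(-n3nc(-c4ccccn4)nc3N)c2cc1OC` is not yet measured; it differs from compound 2 by methyl in place of chloro on an aromatic carbon. Going by the values given here, no step between two measured compounds exists to guide the size of this change. With both measured values at the limit, no change beyond the usual scatter is expected, and the estimated step is a number no higher from compound 2 to compound 3 (the limit leaves the size open). Compound 3 is accordingly expected to give about 40000 nM, within a range from 8000 nM to 200000 nM, and most likely to be reported again only as a limit.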

Compound 3, half-maximal inhibitory concentration: 10100 nM
Beside the measured number, compound 3's estimate is 4.0-fold (0.60 log units) above it; low and high end bracket the measured number.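

The position between two ring nitrogen atoms on this core does affect the result: in this assay methyl in place of chloro produces a step beyond the usual scatter (an at least 3.9-fold lower number from compound 2 to compound 3 (0.59 log units; beyond the scatter)). For the compounds shown here, compound 3 at 10100 nM is the only one of the three compounds to return a number rather than a limit, so a change of one heavy atom is enough to bring this series into the range the test can report. The step can be given only as a minimum, because compound 2 carries a limit and not a number: (the limit of > 40000 nM in this assay, at which 2 of the 3 values shown sit).

As far as these compounds go, whether an ethyl, a methoxy or an amine at this position would give a lower number than methyl stays open. These compounds also cannot say why the swap lowers the number, or whether it would do the same on the core of compound 1.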